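The compounds below may be only part of what the source reports. "The series", "measured", "known", "first", "only" and "open" are said of these compounds alone.

Compound 1 `CN(CCN(C)C(=O)n1cccn1)Cc1ccc(OCc2ccccc2)cc1`: 510 nM
Compound 2 `CN(CCN(C)C(=O)n1cc(C#N)cn1)Cc1ccc(OCc2ccccc2)cc1`: 120 nM
Compound 3 `O=C(NCc1ccc(OC(c2ccccc2)c2ccccc2)cc1)n1cccn1`: > 100000 nM

All three were tested in an assay on membranes from brain for binding affinity to Fatty-acid amide hydrolase 1 (Mus musculus), read by fluorescence, with stated times of 1 h and 30 min; on this read-out lower numbers stand for stronger inhibition and higher numbers for weaker inhibition. Compound 1 and compound 2 share one core and differ in a single spot: cyano in place of hydrogen on an aromatic carbon. That change produced a 4.3-fold lower number from compound 1 to compound 2 (0.63 log units; beyond the scatter). Compound 3 is built on a different core; the difference between the two cores is not broken down here. In this assay compound 3 sits at the limit of > 100000 nM in this assay, at which 1 of the 3 values shown sits, and that value is a limit of the assay rather than a number.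

Compound 4 `N#Cc1cnn(C(=O)NCc2ccc(OC(c3ccccc3)c3ccccc3)cc2)c1` has not yet been measured. It stands to compound 3 exactly as compound 2 stands to compound 1, carrying the same change: cyano in place of hydrogen on an aromatic carbon. Because compound 3 gives only a limit > 100000 nM, no true starting point is known, so the step of an at least 1.4-fold lower number from compound 3 to compound 4 (0.15 log units; that floor lies within the scatter) is expected only as a rough guess shaped by the earlier one. A real chance remains that compound 4 also reports only a limit in this assay. The expected value for compound 4 is 70000 nM, with a range from 15000 nM to 300000 nM.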

Compound 4, half-maximal inhibitory concentration: > 100000 nM
Compound 4 gave a limit, no number (the forecaster's own chance of this, stated with the estimate: 60%); middle value at least 1.4-fold (0.15 log units) from the limit.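

In this assay, compound 3 and compound 4 each give only a limit of the assay, not a number, so no step can be read between them: the limit of > 100000 nM in this assay, at which 2 of the 4 values shown sit.

The compounds shown leave open whether cyano in place of hydrogen changes the read-out at all on the core of compound 3, and what true values lie behind the limit.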